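From Pyrrolidin-1-yl to Dimethylamino at the Chain Carbon

The source may report more compounds than this note shows. Statements on the series, on what has been measured and on what is new or still open speak of the compounds shown alone.

Of the compounds shown here, two carry numbers so far. Compound 1 `Cc1nnc(CN2CCCC2)n1-c1ccc(Cl)cc1C(=O)c1ccccc1Cl` gives 1 mg/kg in a functional assay on the whole organism (strain CF-1) with Mus musculus as the target (a lower number here means that less compound is needed, a higher number that more compound is needed for the effect), the lowest of the two numbers shown, though its only neighbour sits within the scatter of it: compound 2 `Cc1nnc(CN2CCCC2)n1-c1ccc(Cl)cc1C(=O)c1ccccc1` gives 1.3 mg/kg in this assay, and the step of a 1.3-fold higher number from compound 1 to compound 2 (0.11 log units; within the scatter) puts hydrogen in place of chloro on an aromatic carbon, a part of the molecule that is left untouched here.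

Compound 3 `Cc1nnc(CN(C)C)n1-c1ccc(Cl)cc1C(=O)c1ccccc1Cl` is not yet measured. It differs from compound 1 in one place: dimethylamino in place of pyrrolidin-1-yl on a saturated chain carbon bound to an aromatic carbon. Within the data shown here, no measured step touches this position, so the single step that exists shows only that one change of this size elsewhere in the molecule stayed within the scatter. On that thin ground the account expects compound 3 to stay close to compound 1 in this assay, with a step of a 1.5-fold higher number from compound 1 to compound 3 (0.18 log units; within the scatter) that is expected to lie within the usual scatter. The estimate for compound 3 is 1.5 mg/kg, with a range expected to run from 0.5 mg/kg to 4.5 mg/kg.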

Compound 3, dose for half-maximal effect: 0.25 mg/kg
The estimate for compound 3 lay 6.0-fold (0.78 log units) above the measured number, outside the stated range (below it).
By their numbers in this assay, from the lowest: compound 3; then compounds 1 and 2 (each within the scatter of the next).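

In this assay, among these compounds, the change at the saturated chain carbon bound to an aromatic carbon gives the first step in this set that lies beyond the scatter (a 4.0-fold lower number from compound 1 to compound 3 (0.60 log units; beyond the scatter)), at a position that no earlier step had touched. Among the compounds shown here, the only earlier step, on an aromatic carbon (a 1.3-fold higher number from compound 1 to compound 2 (0.11 log units; within the scatter)), stayed within the scatter, so the number is now seen to shift with the amine on this chain carbon, and dimethylamino, which has no ring and fewer heavy atoms, gives the lower number of this pair. No evidence at hand bears on what lies behind this step.

As far as these compounds go, a single pair cannot separate the loss of the ring from the loss of heavy atoms, so it remains open whether diethylamino, an open-chain amine, would follow dimethylamino or pyrrolidin-1-yl, and how piperidin-1-yl or morpholin-4-yl would compare. From the compounds shown here alone, it also remains open whether the step from pyrrolidin-1-yl to dimethylamino would be of similar size with hydrogen in place of chloro on the aromatic carbon.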